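Removing a Methoxy Group From a Nitrobenzyl Aniline

The source may hold more compounds than are shown below. What is called first, only, known or untested is meant among the compounds shown, and "the series" means these compounds.

Compound 2 `COc1ccc(N(Cc2ccc([N+](=O)[O-])cc2)Cc2ccccc2OC)cc1` carries a 2-methoxybenzyl group and a nitrobenzyl group on the same aniline nitrogen. In a functional assay on L929 cells (Mus musculus) for inhibition, read by MTT assay, with a stated time of 5 days (on this read-out lower numbers stand for stronger inhibition and higher numbers for weaker inhibition), compound 2 gives only a limit, > 40 ug/mL, rather than a measured number. Compound 1 `COc1ccc(N(Cc2ccc([N+](=O)[O-])cc2)CC(C)C)cc1` also reaches only the limit of > 40 ug/mL in this assay. Compound 3 `COc1ccc(N(Cc2ccccc2)Cc2ccccc2OC)cc1` likewise gives a limit, > 40 ug/mL. The step that the two limits leave unreadable from compound 1 to compound 2 and the step that the two limits leave unreadable from compound 2 to compound 3 cannot be read, and all three values share (the limit of > 40 ug/mL in this assay, at which 3 of the 3 values shown sit).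

Compound 4 `COc1ccc(N(Cc2ccccc2)Cc2ccc([N+](=O)[O-])cc2)cc1` differs from compound 2 by one change: hydrogen in place of methoxy on an aromatic carbon. Within the data shown here, no measured step covers this exact change, and the two measured steps that touch compound 2 give no size at all. With every known value sitting at the limit, there is no ground to expect compound 4 to turn into a measured number. The estimated step that the limit leaves unreadable from compound 2 to compound 4 is expected to be none beyond the scatter. Compound 4 is therefore expected to fall around 60 ug/mL, within the range 25 ug/mL to 200 ug/mL, most likely again reported only as a limit.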

Compound 4, half-maximal inhibitory concentration: > 40 ug/mL
Compound 4: a limit, no number; the forecaster's own chance of this, stated with the estimate: 80%; the middle value does not contradict the limit.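

Among these compounds, no step from compound 1 or compound 2 to compound 4 can be read, because all the values stop at a limit rather than a number: (the limit of > 40 ug/mL in this assay, at which 4 of the 4 values shown sit). In this assay the compounds shown leave open how strongly any of them inhibits, and whether replacing methoxy with hydrogen changes that at all.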